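The source may hold more compounds than are shown below. What is called first, only, known or untested is meant among the compounds shown, and "the series" means these compounds.

Measured so far:
- Compound 1, `O=C(Nc1nc(-c2cccc(Br)c2)cs1)c1ccc([N+](=O)[O-])o1`: 71000 nM in an ADME assay on Vero cells (Chlorocebus sabaeus) for cytotoxicity, read by MTT assay, with a stated time of 72 h; on this read-out higher numbers stand for weaker inhibition and lower numbers for stronger inhibition
- Compound 2, `CC(=O)Nc1cccc(-c2csc(NC(=O)c3ccc([N+](=O)[O-])o3)n2)c1`: 57600 nM in this assay

Among the compounds with values here, compound 2 stands with the lowest of the two numbers in this assay, but its only neighbour is compound 1, and the step of a 1.2-fold lower number from compound 1 to compound 2 (0.09 log units; within the scatter) lies within the scatter, so the two cannot be told apart.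

Compound 3, `O=C(Nc1nc(-c2cccc(NC(=O)C3CCCCC3)c2)cs1)c1ccc([N+](=O)[O-])o1`, has not been measured. It differs from compound 2 in one place: cyclohexyl in place of methyl on a carbonyl carbon, that is, acetamido becomes (cyclohexylcarbonyl)amino. Within the data shown here, no measured step touches this position in the same way; the only step known, from compound 1 to compound 2, exchanged the whole group on the aromatic carbon and itself stayed within the scatter. There is therefore no firm basis for a direction, and a step near or within the scatter is expected, a 1.4-fold lower number from compound 2 to compound 3 (0.16 log units; within the scatter). Compound 3 is estimated at 40000 nM, within a range of 15000 nM to 100000 nM.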

Compound 3, half-maximal inhibitory concentration: 21900 nM
Compound 3: middle estimate off by 1.8-fold (0.26 log units), on the high side, and the stated range covers the measured number.
By their numbers in this assay, from the lowest: compound 3; then compounds 2 and 1 (each within the scatter of the next).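

Within the data shown here, with cyclohexyl in place of methyl on the carbonyl carbon, this assay shows a 2.6-fold lower number from compound 2 to compound 3 (0.42 log units; beyond the scatter) and so a stronger inhibition of the cells, which makes this the first change to pass beyond the scatter. Exchanging the whole group on the aromatic carbon, with (cyclohexylcarbonyl)amino in place of bromo, gives a 3.2-fold lower number from compound 1 to compound 3 (0.51 log units; beyond the scatter) and this too lies beyond the scatter, whereas acetamido and bromo could not be told apart, so among these three compounds only compound 3 stands apart. Nothing measured here explains why this change lowers the number.

From the compounds shown here alone, it remains open whether the ring itself matters or whether another carbon group would serve as well. A straight hexyl chain or a cyclohexyl carrying an amine on that carbonyl carbon would address this.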